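Chain extension on a shared core, before the measurement

A few compounds are considered here, and "the series" means these few. Any claim that something is new, unique, unknown or untested is made for them only; others in the source may bear on it.

Four compounds on one shared core are followed in a functional assay on A549 cells (Homo sapiens) for inhibition, read by MTT assay, with a stated time of 24 h; on this read-out higher numbers stand for weaker inhibition and lower numbers for stronger inhibition. Compound 1 `CCCCc1cc2ccccc2nc1-c1cc(-c2ccccc2)no1` carries a butyl chain and an unsubstituted phenyl ring; in this assay compound 1 gives > 100000 nM, which is a limit and not a number. Compound 2 `CCCCCc1cc2ccccc2nc1-c1cc(-c2ccccc2)no1` differs from compound 1 by methyl in place of hydrogen on a saturated chain carbon, four bonds along the chain from an aromatic carbon; in this assay compound 2 gives 92300 nM. The step of an at least 1.0-fold lower number from compound 1 to compound 2 (0.03 log units; that floor lies within the scatter) can be read no further, as compound 1 sits at the limit of > 100000 nM in this assay, at which 2 of the 3 values shown sit.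

Compound 3 `CCCc1cc2ccccc2nc1-c1cc(-c2ccc(C)cc2)no1` has the same atoms as compound 1 joined differently; the difference between the two cores is not broken down here. In this assay compound 3 gives > 100000 nM, again a limit rather than a number. Compound 4 `CCCCc1cc2ccccc2nc1-c1cc(-c2ccc(C)cc2)no1` differs from compound 3 by methyl in place of hydrogen on a saturated chain carbon, three bonds along the chain from an aromatic carbon. This is the same kind of change as that between compound 1 and compound 2, though the place differs: four bonds along the chain from an aromatic carbon there, three bonds here. The step is expected to be a step that the limit leaves unreadable from compound 3 to compound 4, resting on the step of an at least 1.0-fold lower number from compound 1 to compound 2 (0.03 log units; that floor lies within the scatter). Compound 4 is accordingly expected to give about 120000 nM, likely between 60000 nM and 300000 nM.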

Compound 4, half-maximal inhibitory concentration: > 100000 nM
Compound 4 gave a limit, no number (the forecaster's own chance of this, stated with the estimate: 60%); the middle value is on the limit's open side.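

In this assay compound 4 gives > 100000 nM as a limit and not a number. The steps from compound 3 and from compound 1 to compound 4 each join two limits, so neither can be read. Left open is how far methyl in place of hydrogen, on the chain or on the aromatic carbon, moves inhibition, as compound 2 alone carries a number.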